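This account rests on a few compounds, and the source may have more. Where it says the series, first, only, none or still open, it means among the compounds named here.

In a functional assay on A2780 cells (Homo sapiens) for inhibition, read by sulforhodamine B assay (on this read-out higher numbers stand for weaker inhibition of growth and lower numbers for stronger inhibition of growth), compound 3 (`Oc1cccc2[nH]c(-c3ccc(-c4ccc(-c5ccc(F)cc5)cc4)cc3)nc12`) gives 41200 nM and sits level with compound 2 (`Fc1ccc(-c2ccc(-c3ccc(-c4nc5ccccc5[nH]4)cc3)cc2)cc1`) at 48200 nM on this scale. Compound 1 (`COc1cc(-c2ccc(-c3ccc(-c4nc5cc(C)ccc5[nH]4)cc3)cc2)cc(OC)c1OC`) stands far lower at 190 nM among the three. Compound 4 (`CN(C)c1ccc(-c2ccc(-c3ccc(-c4nc5c(O)cccc5[nH]4)cc3)cc2)cc1`) alters compound 3 in one place, with dimethylamino in place of fluoro on an aromatic carbon. Among the compounds with values here, the only measured single change is a 1.2-fold lower number from compound 2 to compound 3 (0.07 log units; within the scatter) for hydroxy in place of hydrogen, and it lies elsewhere in the molecule, so nothing measured tests this swap directly. Compound 1 at 190 nM shows that molecules with this shared core can reach far lower numbers, although it differs from compound 3 in several places. The expected step is an 8.2-fold lower number from compound 3 to compound 4 (0.92 log units; beyond the scatter) in this assay and remains an uncertain estimate. For compound 4 the estimated value is 5000 nM (expected range 500 nM to 45000 nM).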

Compound 4, concentration for 50% growth inhibition: 3010 nM
Beside the measured number, compound 4's estimate is 1.7-fold (0.22 log units) above it, within the range that was stated.
By their numbers in this assay, from the lowest: compound 1; then compound 4; then compounds 3 and 2 (each within the scatter of the next).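

In this assay, the group at this position, para to a large group, clearly counts: dimethylamino in place of fluoro gives a 14-fold lower number from compound 3 to compound 4 (1.14 log units; beyond the scatter) and so moves the number well beyond the scatter. Within the data shown here, the only earlier single change, hydroxy in place of hydrogen elsewhere in the molecule, gave just a 1.2-fold lower number from compound 2 to compound 3 (0.07 log units; within the scatter) and showed no such shift. Nothing measured here explains why this swap has so large an effect.

From the compounds shown here alone, whether a plain amine or a carboxylic acid at this position would give a lower or higher number stays open. So does whether dimethylamino has the same effect on a core without the hydroxy.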